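Swapping the amide for a fluorinated carbinol on the para position

A few compounds are considered here, and "the series" means these few. Any claim that something is new, unique, unknown or untested is made for them only; others in the source may bear on it.

Three compounds share one core and differ only at a single aromatic carbon. Compound 3 `CC#C[C@H]1CN(S(=O)(=O)c2ccc(N)nc2)CCN1c1ccc(C(=O)NC)cc1` carries a methylcarbamoyl group there, and in an ADME assay (liver) for metabolic stability, with Liver microsome (Rattus norvegicus) as the target, using microsomes and NADPH, with a stated time of 30 min (on this read-out higher numbers stand for fast clearance and lower numbers for slow clearance), compound 3 gives 41 mL.min-1.g-1. That is the lowest of the two numbers available: compound 1 `CC#C[C@H]1CN(S(=O)(=O)c2ccc(N)nc2)CCN1c1ccc(C(O)(COC)C(F)(F)F)cc1`, which bears the methoxymethyl-substituted trifluoromethyl carbinol, gives 93 mL.min-1.g-1 in this assay, and the step of a 2.3-fold lower number from compound 1 to compound 3 (0.36 log units; beyond the scatter) lies beyond the scatter. Compound 2 `CC#C[C@H]1CN(S(=O)(=O)c2ccc(N)nc2)CCN1c1ccccc1`, with only a hydrogen at that position, returns a limit rather than a number, > 399 mL.min-1.g-1; this is the limit of > 399 mL.min-1.g-1 in this assay, at which 1 of the 3 values shown sits. The step of an at least 9.7-fold lower number from compound 2 to compound 3 (0.98 log units; beyond the scatter) and the step of an at least 4.2-fold higher number from compound 1 to compound 2 (0.63 log units; beyond the scatter) are therefore only bounds.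

Compound 4 `CC#C[C@H]1CN(S(=O)(=O)c2ccc(N)nc2)CCN1c1ccc(C(O)(CC#N)C(F)(F)F)cc1` has not been measured. It differs from compound 3 by a group of 9 heavy atoms (4 carbon, 1 nitrogen, 1 oxygen, 3 fluorine; no ring) in place of a group of 4 heavy atoms (2 carbon, 1 nitrogen, 1 oxygen; no ring), on an aromatic carbon, the new group being a trifluoromethyl carbinol whose chain ends in a nitrile. Within the data shown here, the closest precedent is the step from compound 1 to compound 3, in which a carbinol of the same size gave way to methylcarbamoyl and clearance fell modestly. Reversing that direction, the step of a 2.0-fold higher number from compound 3 to compound 4 (0.29 log units; within the scatter) is expected to raise clearance by a similarly modest margin. Compound 4 is thus estimated to show 80 mL.min-1.g-1 in this assay, with a plausible range from 40 mL.min-1.g-1 to 160 mL.min-1.g-1.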

Compound 4, intrinsic clearance in microsomes: 57 mL.min-1.g-1
The estimate for compound 4 lay 1.4-fold (0.15 log units) above the measured number; measured number inside the range.
By their numbers in this assay, from the lowest: compounds 3, 4 and 1 (each within the scatter of the next, the first and the last beyond it). At a limit, above all of these: compound 2.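

Compound 4 shows that a trifluoromethyl carbinol at this position can read much like methylcarbamoyl in this assay: the step of a 1.4-fold higher number from compound 3 to compound 4 (0.14 log units; within the scatter) leaves the two groups without an order. Changing the end of the carbinol chain, with cyano in place of methoxy, gives the step of a 1.6-fold lower number from compound 1 to compound 4 (0.21 log units; within the scatter), so compound 4 lies within the scatter of both compound 1 and compound 3, even though those two compounds lie beyond the scatter of each other. The carbinol of compound 4 also stands well apart from the bare hydrogen, but the step of an at least 7.0-fold lower number from compound 2 to compound 4 (0.84 log units; beyond the scatter) is only a bound, and compound 2 stands at a limit of the assay rather than at a number: the limit of > 399 mL.min-1.g-1 in this assay, at which 1 of the 4 values shown sits.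

The compounds shown do not separate the share of the hydroxyl from that of the trifluoromethyl on the carbinol carbon, as both are present in compound 1 and compound 4. Also open, going by these compounds, is how a carbinol chain ending in an amine or a carboxylic acid, or a longer chain, would read in this assay.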